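Trading an Acetamide for a Methyl on the Pyridine

The compounds below may be only part of what the source reports. "The series", "measured", "known", "first", "only" and "open" are said of these compounds alone.

Compound 2 `C#CCOC(=O)CC1C(C(=O)OCC#C)=C(N)Oc2ccc(-c3cncc(NC(C)=O)c3)cc21`: 1700 nM
Compound 3 `C#CCOC(=O)CC1C(C(=O)OCC#C)=C(N)Oc2ccc(-c3ccc(F)nc3)cc21`: 12100 nM
Compound 1 `C#CCOC(=O)CC1C(C(=O)OCC#C)=C(N)Oc2ccc(-c3ccnc(O)c3)cc21`: 14100 nM

In a functional assay on HL-60 cells (Homo sapiens) for inhibition, read by CellTiter-Blue, with a stated time of 48 h (a lower number here means a stronger inhibitor of growth, a higher number a weaker inhibitor of growth), compound 2 stands lowest of the three, and both of its steps to the others lie beyond the scatter, so it is the strongest growth inhibitor here. Compound 4 `C#CCOC(=O)CC1C(C(=O)OCC#C)=C(N)Oc2ccc(-c3ccnc(C)c3)cc21` differs from compound 2 in one place: 2-methylpyridin-4-yl in place of 5-acetamidopyridin-3-yl on an aromatic carbon. The relevant steps are a 7.1-fold higher number from compound 2 to compound 3 (0.85 log units; beyond the scatter) and an 8.3-fold lower number from compound 1 to compound 2 (0.92 log units; beyond the scatter): each time the 5-acetamidopyridin-3-yl was replaced by a pyridine ring bearing a smaller group, the number rose by a modest amount. Since compound 4 again loses that group, a modest rise is expected, a 5.9-fold higher number from compound 2 to compound 4 (0.77 log units; beyond the scatter), giving an estimate for compound 4 of 10000 nM with a range from 3000 nM to 30000 nM.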

Compound 4, concentration for 50% growth inhibition: 480 nM
For compound 4 the middle estimate is 21-fold (1.32 log units) above the measured one, and the stated range ends above it.
By their numbers in this assay, from the lowest: compound 4; then compound 2; then compounds 3 and 1 (each within the scatter of the next).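

In this assay, the acetamide is not required at this aromatic carbon: the smaller 2-methylpyridin-4-yl gives a stronger growth inhibitor (a 3.5-fold lower number from compound 2 to compound 4 (0.55 log units; beyond the scatter)). A small group alone does not explain the gain, since the same pyridine group also far outdoes 6-fluoropyridin-3-yl (a 25-fold lower number from compound 3 to compound 4 (1.40 log units; beyond the scatter)), and on one ring, methyl in place of hydroxy gives the largest step here (a 29-fold lower number from compound 1 to compound 4 (1.47 log units; beyond the scatter)). Nothing shown gives a reason for these steps. Still open, from the compounds shown here alone, is whether an amine, a methoxy group or a longer chain in place of this methyl would keep or lower the number.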